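Hydroxycyclohexane carboxamide amino-acid series: branched side chain

A few compounds are considered here, and "the series" means these few. Any claim that something is new, unique, unknown or untested is made for them only; others in the source may bear on it.

Measured so far:
compound 1, `O=C(O)CNC(=O)[C@]1(O)C[C@@H](O)[C@@H](O)[C@H](O)C1`: 38%
compound 2, `O=C(O)CC[C@H](NC(=O)[C@]1(O)C[C@@H](O)[C@@H](O)[C@H](O)C1)C(=O)O`: 43%
compound 3, `C[C@H](NC(=O)[C@]1(O)C[C@@H](O)[C@@H](O)[C@H](O)C1)C(=O)O`: 30%

All three were run in an assay on HL-60 cells for inhibition of E-selectin (Homo sapiens), tested at 50 mM; on this read-out higher numbers stand for more inhibition at the one concentration tested (going by the name of the read-out) and lower numbers for less inhibition. Compound 3 gives the lowest of the three numbers in this assay; against compound 1 the gap is a number 8 percentage points lower from compound 1 to compound 3 (within the scatter), which is within the scatter, while against compound 2 it is a number 13 percentage points lower from compound 2 to compound 3 (beyond the scatter), a modest gap beyond the scatter. Compound 1 and compound 2 differ by a number 5 percentage points higher from compound 1 to compound 2 (within the scatter), again within the scatter.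

Compound 4, `CCC(C)[C@H](NC(=O)[C@]1(O)C[C@@H](O)[C@@H](O)[C@H](O)C1)C(=O)O`, is the next compound for this assay. The change from compound 3 is sec-butyl in place of methyl on a saturated chain carbon bound to an amide-type nitrogen and a carbonyl carbon.

Within the data shown here, the only measured step at the same place is a number 8 percentage points lower from compound 1 to compound 3 (within the scatter), which stayed within the scatter, so a further enlargement of the alkyl group there has no direct precedent. The other steps alter a different part of the chain and show, at most, a modest movement. Among the measured compounds shown here, no measured step supports a shift beyond the scatter for the step to compound 4, so the expected step is a number 1 percentage points higher from compound 3 to compound 4 (within the scatter), essentially flat.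

Compound 4 is therefore estimated at 31% in this assay, with a range from 16% to 46%.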

Compound 4, a percentage reported as inhibition, at one concentration (the size of the read-out at that concentration, not a potency): 44%
Compound 4: middle estimate off by 13 percentage points, on the low side, within the range that was stated.
By their numbers in this assay, from the lowest: compounds 3, 1, 2 and 4 (each within the scatter of the next, the first and the last beyond it).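

At the saturated chain carbon bound to an amide-type nitrogen and a carbonyl carbon, sec-butyl in place of methyl gives a step beyond the scatter in this assay: a number 14 percentage points higher from compound 3 to compound 4 (beyond the scatter), whereas the earlier step at this place, hydrogen to methyl, stayed within it. Sec-butyl set against the other groups at this place gives a number 6 percentage points higher from compound 1 to compound 4 (within the scatter) and a number 1 percentage points higher from compound 2 to compound 4 (within the scatter), so among these compounds the side-chain carboxylic acid of compound 2 is not needed to reach that level, and the gain over methyl does not carry over to a gain over hydrogen. No measurement in hand explains why sec-butyl stands apart from methyl here.

On these data alone, with only methyl and sec-butyl as alkyl groups at this place, it stays open whether the step follows the number of carbons or the branching, which an unbranched butyl chain or an isopropyl group would help to separate. Also open, as far as these compounds go, is how an amine at the end of a longer chain, or a phenyl ring, would read at this place in this assay.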